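A chloro on the benzyl of a picomolar depsipeptide

A few compounds are considered here, and "the series" means these few. Any claim that something is new, unique, unknown or untested is made for them only; others in the source may bear on it.

Compound 1 `C/C=C(\C)[C@@H](O)[C@@H](C)[C@@H]1C/C=C(\C)C(=O)O[C@H](CC(C)C)C(=O)N[C@@H](C)C(=O)N(C)[C@H](Cc2ccccc2)C(=O)N(C)CC(=O)N[C@@H]([C@@H](C)CC)C(=O)N[C@H](C)C(=O)O1` gives the lowest of the two numbers in a functional assay on A549 cells (Homo sapiens) for cytotoxicity, read by CellTiter-Blue, with a stated time of 72 h (on this read-out lower numbers stand for stronger inhibition and higher numbers for weaker inhibition), namely 0.0014 nM. Compound 2 `C/C=C(\C)[C@@H](O)[C@@H](C)[C@@H]1C/C=C(\C)C(=O)O[C@H](CC(C)C)C(=O)N[C@H](C)C(=O)N(C)[C@H](Cc2ccccc2)C(=O)N(C)CC(=O)N[C@@H]([C@@H](C)CC)C(=O)N[C@H](C)C(=O)O1` gives 1080 nM; the step of a 770000-fold higher number from compound 1 to compound 2 (5.89 log units; beyond the scatter) rests on (the fact that compounds 1 and 2 differ only in the configuration as drawn). Compound 3 `C/C=C(\C)[C@@H](O)[C@@H](C)[C@@H]1C/C=C(\C)C(=O)O[C@H](CC(C)C)C(=O)N[C@@H](C)C(=O)N(C)[C@H](Cc2ccc(Cl)cc2)C(=O)N(C)CC(=O)N[C@@H]([C@@H](C)CC)C(=O)N[C@H](C)C(=O)O1` differs from compound 1 by chloro in place of hydrogen on an aromatic carbon. Within the data shown here, no measured step touches the benzyl group; the single known step concerns configuration alone and does not bear on this change. One therefore expects no step beyond the scatter, a 1.1-fold higher number from compound 1 to compound 3 (0.03 log units; within the scatter). For compound 3 the estimate is 0.0015 nM, expected to fall between 0.0003 nM and 0.01 nM.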

Compound 3, half-maximal inhibitory concentration: 0.00002 nM
Compound 3: the middle estimate sits 75-fold (1.88 log units) above what was measured; the whole stated range lies above it.
By their numbers in this assay, from the lowest: compound 3; then compound 1; then compound 2.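

In this assay chloro in place of hydrogen on the aromatic ring gives a 70-fold lower number from compound 1 to compound 3 (1.85 log units; beyond the scatter) and so shows that the benzyl group is not a silent place on this depsipeptide. Benzyl to 4-chlorobenzyl is the first step shown that goes to a lower number from compound 1, and a single heavy atom is enough for it. Among these compounds, the only evidence at hand concerns configuration and does not bear on this change. As far as these compounds go, whether the gain belongs to chloro in particular stays open, since a fluoro, a methoxy or an amine on the same carbon would tell. Also open, from the compounds shown here alone, is whether 4-chlorobenzyl acts alike on the configuration drawn in compound 2.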